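From 4-methylphenyl to 4-ethoxyphenyl on a shared core

The compounds below may be only part of what the source reports. "The series", "measured", "known", "first", "only" and "open" are said of these compounds alone.

Among the measured compounds shown here, in a functional assay on L1210 cells (Mus musculus) for antiproliferative activity (on this read-out higher numbers stand for weaker inhibition and lower numbers for stronger inhibition), compound 3 `COc1cc(C(=O)c2sc(-c3ccc(C)cc3)cc2N)cc(OC)c1OC` gives 18 nM, the lowest of the actual numbers so far. Compound 2 `COc1ccc(-c2cc(N)c(C(=O)c3cc(OC)c(OC)c(OC)c3)s2)cc1OC` gives 40 nM. Compound 1 `COc1cc(C(=O)c2sc(-c3ccc(-c4ccccc4)cc3)cc2N)cc(OC)c1OC` reads > 10000 nM, which is a limit of the assay and not a number.

Compound 4 `CCOc1ccc(-c2cc(N)c(C(=O)c3cc(OC)c(OC)c(OC)c3)s2)cc1` differs from compound 3 in one place: ethoxy in place of methyl on an aromatic carbon. For the measured compounds named here, two measured steps bear on this change. The step of an at least 550-fold lower number from compound 1 to compound 3 (2.74 log units; beyond the scatter) came with methyl in place of phenyl, and it was large. The step of a 2.2-fold lower number from compound 2 to compound 3 (0.35 log units; beyond the scatter) came with 4-methylphenyl in place of 3,4-dimethoxyphenyl, and it was modest. This second step is the closer guide, with oxygen on that ring in both compound 2 and compound 4. A modest move towards a higher number is therefore expected, with an estimated size of a 1.7-fold higher number from compound 3 to compound 4 (0.22 log units; within the scatter). In this assay, compound 4 is estimated at 30 nM, with an expected range of 10 nM to 100 nM.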

Compound 4, half-maximal inhibitory concentration: 590 nM
Beside the measured number, compound 4's estimate is 20-fold (1.29 log units) below it; the whole stated range lies below it.
By their numbers in this assay, from the lowest: compound 3; then compound 2; then compound 4. At a limit, above all of these: compound 1.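

Oxygen on this ring does not by itself set the level: the step of a 15-fold higher number from compound 2 to compound 4 (1.17 log units; beyond the scatter) shows that ethoxy behaves very differently from the 3,4-dimethoxyphenyl pattern, and the step of a 33-fold higher number from compound 3 to compound 4 (1.52 log units; beyond the scatter) shows how much one group at this place can count. Compound 1 carries a limit and not a number, so the step of an at least 16-fold lower number from compound 1 to compound 4 (1.22 log units; beyond the scatter) has only a lower bound on its size: the limit of > 10000 nM in this assay, at which 1 of the 4 values shown sits. Nothing given here explains the rise in compound 4.

Open, on these data alone, is how a single methoxy, a longer chain such as propoxy, or an amine would read at this place. Also open, as far as these compounds go, is whether the rise continues with chain length.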